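A few compounds are considered here, and "the series" means these few. Any claim that something is new, unique, unknown or untested is made for them only; others in the source may bear on it.

Measured so far in a functional assay (Left cardiac atrium, Cavia porcellus), with a stated time of 30 min; a higher number here means that more compound is needed for the effect, a lower number that less compound is needed:

- compound 1 `CC1=CSC(O)(c2ccccc2)c2noc(=O)n21` gives 230 nM
- compound 2 `COc1cccc(C2(OCC(F)(F)F)SC=C(C)n3c2noc3=O)c1` gives 320 nM
- compound 3 `COc1ccccc1C1(O)SC=C(C)n2c1noc2=O` gives 930 nM

Compound 3 has the highest number of the three, so it needs the most compound for the effect. Compound 4 `CCOC1(c2ccccc2OC)SC=C(C)n2c1noc2=O` differs from compound 3 in one place: ethyl in place of hydrogen on an oxygen on a saturated carbon, which turns hydroxy into ethoxy ethyl in place of hydrogen on an oxygen on a saturated carbon as counted here.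

Going by the values given here, no measured step makes this same change. The only one available is a 4.0-fold higher number from compound 1 to compound 3 (0.61 log units; beyond the scatter) and it is methoxy in place of hydrogen on an aromatic carbon, so it bears only indirectly, by showing how far one small change can move a number in this set. Compound 2 also has no hydroxy on that saturated carbon, and compound 2 shows 320 nM as its value, but it differs from compound 3 in more than one place, so this is a weak hint.

A small step toward a lower number is therefore expected, smaller than the measured one and perhaps no larger than the scatter. The expected change is a 1.7-fold lower number from compound 3 to compound 4 (0.23 log units; within the scatter) and its margin is wide. For compound 4 the estimated value is 550 nM with an expected range from 170 nM to 1700 nM in this assay.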

Compound 4, half-maximal effective concentration: 140 nM
For compound 4 the middle estimate is 3.9-fold (0.59 log units) above the measured one; the whole stated range lies above it.
By their numbers in this assay, from the lowest: compounds 4, 1 and 2 (each within the scatter of the next, the first and the last beyond it); then compound 3.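

In this assay, replacing hydroxy with ethoxy on the saturated carbon gives a 6.6-fold lower number from compound 3 to compound 4 (0.82 log units; beyond the scatter), the first single-place step at this position among the compounds shown. Going by these compounds alone, the only earlier step of this kind, a 4.0-fold higher number from compound 1 to compound 3 (0.61 log units; beyond the scatter), was a change on an aromatic carbon and went towards needing more compound, so it said nothing about the oxygen on the saturated carbon. The new step shows that this oxygen can carry an ethyl group in place of its hydrogen without any loss in this assay, and that the hydrogen is not required for the effect here, while less compound is in fact needed; no available measurement accounts for the size or direction of this step.

As far as these compounds go, with a single step at this oxygen, it remains open whether a smaller group such as methyl or a longer chain such as butyl would move the number further, or whether an amine on the saturated carbon in place of the ethoxy would be tolerated. From the compounds shown here alone, it is also open whether the same swap of hydroxy for ethoxy would act alike on compound 1, which has no methoxy on its aromatic ring.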